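Phenyl in Place of Cyclohexyl on the Chain Carbon

The source may report more compounds than this note shows. Statements on the series, on what has been measured and on what is new or still open speak of the compounds shown alone.

Measured so far:
compound 1, `O=C(NCC1CCCCC1)N1C(=O)c2ccccc2S1(=O)=O`: > 166 h
compound 2, `O=C(NCc1cccc(Br)c1)N1C(=O)c2ccccc2S1(=O)=O`: > 166 h

In a physicochemical assay for pharmacokinetics (a lower number here means that the compound disappears faster, a higher number that the compound lasts longer), compound 1 gives > 166 h, which is a limit of the assay and not a number. In this assay compound 2 gives > 166 h, again only a limit. Among the measured compounds shown here, the one measured step, a step that the two limits leave unreadable from compound 1 to compound 2, therefore cannot be read in size, and the limit of > 166 h in this assay, at which 2 of the 2 values shown sit, is all the two values tell.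

Compound 3, `O=C(NCc1ccccc1)N1C(=O)c2ccccc2S1(=O)=O`, differs from compound 1 by phenyl in place of cyclohexyl on a saturated chain carbon bound to an amide-type nitrogen. The change is of the same kind as the measured step, yet that step gives no size. Since compound 2 with its 3-bromophenyl already sits at the limit, compound 3 is expected to sit there too, with a step that the limit leaves unreadable from compound 1 to compound 3 not beyond the scatter. Compound 3 is estimated at 250 h, between 120 h and 600 h.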

Compound 3, half-life: > 166 h
Compound 3 ended at the assay's limit; the forecaster's own chance of this, stated with the estimate: 85%; the middle value does not contradict the limit.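

Among the compounds shown here, no step between compound 1, compound 2 and compound 3 can be read in this assay because all three results are limits of the assay and not numbers: the limit of > 166 h in this assay, at which 3 of the 3 values shown sit. The compounds shown leave open how long each one actually lasts and whether cyclohexyl, phenyl and 3-bromophenyl differ at all.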